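A few compounds are considered here, and "the series" means these few. Any claim that something is new, unique, unknown or untested is made for them only; others in the source may bear on it.

Measured compounds:
- compound 1 `O=C(CCCCC1CCSS1)Nc1cccc2ccccc12`: "not active" (no number reported)
- compound 2 `O=C(CCCCC(S)CCS)Nc1ccccc1`: 5.49%
- compound 3 `O=C(CCCCC(S)CCS)Nc1cccc(C(F)(F)F)c1`: 8.86%

These results come from a functional assay on HO8910 cells (Homo sapiens) for inhibition, read by MTT assay, with a stated time of 24 h, tested at 10 ug/mL; on this read-out higher numbers stand for more inhibition of growth at the one concentration tested and lower numbers for less inhibition of growth. There, compound 1 is reported as "not active" (no number reported), with no single number, so it offers no numerical starting point.

Compound 4 `O=C(CCCCC(S)CCS)Nc1cccc2ccccc12` keeps the amide part of compound 1 but opens the sulfur-containing ring: a group of 5 heavy atoms (3 carbon, 2 sulfur; no ring) in place of a group of 5 heavy atoms (3 carbon, 2 sulfur; one five-membered non-aromatic ring with 2 hetero atoms), on a saturated chain carbon, four bonds along the chain from a carbonyl carbon. Within the data shown here, no measured step makes this same change. Among the measured compounds shown here, the one step available, a number 3.4 percentage points higher from compound 2 to compound 3 (within the scatter), is a different change on an aromatic carbon, and it shows only that this replacement left the value within the scatter.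

The better guide is the open 1,3-disulfanylpropyl group itself, which compound 4 shares with compounds 2 and 3. Compound 2 gives 5.49% and compound 3 gives 8.86% with that group in place. The step from compound 1 therefore cannot be sized, but only weak inhibition is expected, with no large rise in this assay. For compound 4, the estimated value is 9%, with an expected range from 2% to 22%.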

Compound 4, percent growth inhibition at one concentration: "not active" (no number reported)
For compound 4 the study gives words and no number, and the estimate cannot be compared.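

In this assay, compound 1 and compound 4 are both reported in words without a number, so no new step can be read from this pair. Going by these compounds, how opening the sulfur-containing ring changes growth inhibition stays open, and no supporting measurement bears on this result.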